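The compounds below may be only part of what the source reports. "The series", "measured", "known", "first", "only" and "open" are said of these compounds alone.

Compound 1, `COCNc1n[n+]([O-])c2ccccc2[n+]1[O-]`, carries a short methoxymethyl arm on the amino nitrogen of its core. For the measured compounds named here, in a functional assay on PC-3 cells (Homo sapiens) for cytotoxicity, read by MTT assay, with a stated time of 72 h (on this read-out lower numbers stand for stronger inhibition and higher numbers for weaker inhibition), compound 1 gives 7510 nM, the highest of the two numbers so far. Its nearest neighbour is compound 2, `COc1ccc2c(c1)[n+]([O-])nc(NCOC(C)c1ccccc1)[n+]2[O-]`, which bears a methoxy group on the core and a longer, phenyl-containing arm on the nitrogen; in this assay compound 2 gives 4140 nM, a number that sits within the usual scatter of compound 1, so the two cannot be told apart on these figures.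

Compound 3, `CCCCCCCOCNc1n[n+]([O-])c2ccccc2[n+]1[O-]`, keeps the core of compound 1 unchanged and alters only the arm: hexyl in place of hydrogen on a saturated chain carbon bound to an oxygen on a saturated carbon. Going by the values given here, no measured pair shows this kind of lengthening, so the expectation rests on the two numbers in hand. Compound 2, with its larger arm, gave a figure no different from compound 1 beyond the scatter, which argues against a dramatic shift. Compound 3 is therefore expected to give a modest step of a 2.1-fold lower number from compound 1 to compound 3 (0.33 log units; beyond the scatter) toward a lower number, and its value in this assay is estimated at 3500 nM, most likely between 1200 nM and 10000 nM.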

Compound 3, half-maximal inhibitory concentration: 1210 nM
Estimate against measurement, compound 3: 2.9-fold (0.46 log units) above; the range from low to high includes it.
By their numbers in this assay, from the lowest: compound 3; then compounds 2 and 1 (each within the scatter of the next).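

The arm of compound 1 gives a 6.2-fold lower number from compound 1 to compound 3 (0.79 log units; beyond the scatter) in this assay when hexyl replaces hydrogen on a saturated chain carbon bound to an oxygen on a saturated carbon, while the core stays unchanged. For the compounds shown here, this is the first pair here that differs in one place only, so it is the first reading of this position on its own: a change made in the arm alone is enough to move the number beyond the scatter, and it moves it toward stronger inhibition. No measurement here bears on why the number moves, so the reason for the step remains unknown.

As far as these compounds go, a single step gives one point and no trend, so it remains open whether a shorter chain such as propyl would give part of this change, and whether a longer chain such as decyl would extend it or reverse it. From the compounds shown here alone, it is also open whether the step depends on the chain alone or would hold with an amine or a carboxylic acid at the end of the hexyl chain, and whether hexyl would act the same way on a core bearing a methoxy group.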